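A few compounds are considered here, and "the series" means these few. Any claim that something is new, unique, unknown or untested is made for them only; others in the source may bear on it.

In an ADME assay on HepG2 cells (Homo sapiens) for cytotoxicity (on this read-out lower numbers stand for higher toxicity in this test and higher numbers for lower toxicity in this test), compound 1 `CN1CCN(CC#Cc2cc3c(Nc4ccc(OCc5cccc(F)c5)c(Cl)c4)ncnc3s2)CC1` gives 15 uM. Compound 2 `CCOC(=O)CN(C)CC#Cc1cc2c(Nc3ccc(OCc4cccc(F)c4)c(Cl)c3)ncnc2s1` gives > 28 uM, which is a limit and not a number, and it therefore stands at the limit of > 28 uM in this assay, at which 1 of the 2 values shown sits. Compound 3 `CC(C)(C)CC#Cc1cc2c(Nc3ccc(OCc4cccc(F)c4)c(Cl)c3)ncnc2s1` follows from compound 2 by this change: tert-butyl in place of ((ethoxycarbonyl)methyl)(methyl)amino on a saturated chain carbon bound to a triple-bonded carbon. It places tert-butyl on a saturated chain carbon bound to a triple-bonded carbon. Going by the values given here, the one measured step bearing on this change, at the same place, is an at least 1.8-fold higher number from compound 1 to compound 2 (0.27 log units; that floor lies within the scatter). Among the compounds with values here, that step does not show a size beyond the scatter, and no measured step covers the entry of tert-butyl. No step beyond the scatter is therefore expected in this assay, and no direction can be assigned. The expected step is an at least 1.1-fold lower number from compound 2 to compound 3 (0.04 log units; that floor lies within the scatter). For compound 3 the estimated value is 25 uM, with an expected range from 10 uM to 60 uM.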

Compound 3, half-maximal toxic concentration: > 32 uM
Compound 3: a limit, no number; the forecaster's own chance of this, stated with the estimate: 45%; at least 1.2-fold (0.10 log units) between middle value and limit.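

In this assay compound 3 gives > 32 uM, which is a limit of the assay and not a number. Going by these compounds alone, replacing 4-methylpiperazin-1-yl with tert-butyl on a saturated chain carbon bound to a triple-bonded carbon gives the first step that lies beyond the scatter, an at least 2.1-fold higher number from compound 1 to compound 3 (0.32 log units; beyond the scatter), so an all-carbon group here, with no nitrogen, is enough for a reading clear of that of compound 1. No step can be read between compound 2 and compound 3, because both values are limits: the limit of > 32 uM in this assay, at which 1 of the 3 values shown sits.

From the compounds shown here alone, how far the true values of compound 2 and compound 3 lie from their limits remains open, and so does any order between them. Also open, going by these compounds, is how a free carboxylic acid in place of the ethyl ester, a primary amine or a longer alkyl chain would read at this place in this assay.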